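The compounds below may be only part of what the source reports. "The series", "measured", "known", "first", "only" and "open" are said of these compounds alone.

Working notes on the series. All three compounds share one core and differ only in the substituent on one aromatic carbon. Within the data shown here, compound 1 `CC(=O)N(C)c1cccc2c1nc(-c1c(F)cccc1F)n2Cc1c(F)cccc1F` is the first of them; in a toxicity assay on CCRF-CEM cells (Homo sapiens) for cytotoxicity (on this read-out lower numbers stand for higher toxicity in this test and higher numbers for lower toxicity in this test), compound 1 reaches only > 100 uM, which is a limit of the test and not a number. Among the measured compounds shown here, compound 2 `N=C(NO)c1cccc2c1nc(-c1c(F)cccc1F)n2Cc1c(F)cccc1F` is the second; in this assay compound 2 gives 23.1 uM, the only number in the set. The measured step of an at least 4.3-fold lower number from compound 1 to compound 2 (0.63 log units; beyond the scatter) is the only one available, and its full size is not known because it rests on (the limit of > 100 uM in this assay, at which 1 of the 2 values shown sits).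

Compound 3 `Fc1cccc(F)c1Cn1c(-c2c(F)cccc2F)nc2c(CCl)cccc21` is the unmeasured member. Relative to compound 2 the change is a group of 2 heavy atoms (1 carbon, 1 chlorine; no ring) in place of a group of 4 heavy atoms (1 carbon, 2 nitrogen, 1 oxygen; no ring), on an aromatic carbon. For the measured compounds named here, no measured step involves chloromethyl, so the step to compound 3 has no direct precedent; the one measured step shows only that changing this substituent can move this assay beyond the scatter. The expected step in this assay is a 1.5-fold lower number from compound 2 to compound 3 (0.19 log units; within the scatter). For compound 3 the estimate in this assay is 15 uM, with a range from 3 uM to 70 uM.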

Compound 3, half-maximal toxic concentration: 13.4 uM
Compound 3: middle estimate off by 1.1-fold (0.05 log units), on the high side, and the stated range covers the measured number.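

Chloromethyl, with 0 hydrogen-bond donors and 0 hydrogen-bond acceptors, replaces a group with 3 hydrogen-bond donors and 2 hydrogen-bond acceptors, yet in this assay the step stays within the scatter (a 1.7-fold lower number from compound 2 to compound 3 (0.24 log units; within the scatter)). On this aromatic carbon of the shared core, a measurable number in this test therefore does not depend on the hydrogen-bond donors and acceptors of the group in compound 2, and compound 2 and compound 3 cannot be told apart here. The step from the acetyl(methyl)amino group of compound 1 to chloromethyl lies beyond the scatter (an at least 7.4-fold lower number from compound 1 to compound 3 (0.87 log units; beyond the scatter)), so two quite different substituents now both stand clearly apart from compound 1 in the same direction, and what sets compound 1 apart is not yet tied to any one feature.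

An amine, a carboxylic acid or a longer chain on this carbon would show whether the low numbers extend to other groups, and the series gives no reading for any of them. The full size of both steps from compound 1 stays open, as compound 1 is recorded only as a limit and not as a number: the limit of > 100 uM in this assay, at which 1 of the 3 values shown sits.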